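Fluorines on the far ring: compound 2 to compound 4

The source may report more compounds than this note shows. Statements on the series, on what has been measured and on what is new or still open speak of the compounds shown alone.

Measured so far:
- compound 1, `O=C(O)CCCc1cn(CC(=O)O)c2c(/C=C/c3ccc(OCCCCc4c(F)ccc(F)c4F)cc3)cccc12`: 2.1 nM
- compound 2, `Cc1c(CCCC(=O)O)c2cccc(/C=C/c3ccc(OCCCCc4ccccc4)cc3)c2n1CC(=O)O`: 4.7 nM
- compound 3, `Cc1c(Cl)cccc1CCCCOc1ccc(C#Cc2cccc3c(CCC(=O)O)c(C)n(CCCCC(=O)O)c23)cc1`: 60 nM

All three numbers come from a functional assay on HEK293 cells for antagonist activity at cysteinyl leukotriene receptor 2 (Homo sapiens), read by fluorescence and calcium flux, with stated times of 30 min and 1 h; on this read-out lower numbers stand for stronger inhibition and higher numbers for weaker inhibition. Among them compound 2 stands second highest: compound 1 gives a lower number, and compound 3 a much higher one, both gaps lying beyond the usual scatter. Compound 1 also carries a fluorinated ring at the end of its chain, though it differs from compound 2 in more than one place, so its value serves only as loose context.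

The unmeasured compound 4, `Cc1c(CCCC(=O)O)c2cccc(/C=C/c3ccc(OCCCCc4c(F)cc(F)c(F)c4F)cc3)c2n1CC(=O)O`, keeps the core and chain of compound 2 and changes only the ring at the chain end: 2,3,4,6-tetrafluorophenyl in place of phenyl on a saturated chain carbon, four bonds along the chain from an oxygen on an aromatic ring.

Given that compound 2 already gives 4.7 nM and compound 1, with its own fluorinated ring, gives 2.1 nM, the step from compound 2 to compound 4 is expected to be small, within the scatter or modestly toward a lower number, as a 1.6-fold lower number from compound 2 to compound 4 (0.19 log units; within the scatter). Compound 4 is therefore estimated at 3 nM, in a range from 1 nM to 9 nM.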

Compound 4, half-maximal inhibitory concentration: 2.2 nM
Estimate against measurement, compound 4: 1.4-fold (0.13 log units) above; the range from low to high includes it.
By their numbers in this assay, from the lowest: compounds 1 and 4 (each within the scatter of the next); then compound 2; then compound 3.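

In this assay, putting 2,3,4,6-tetrafluorophenyl in place of phenyl on a saturated chain carbon, four bonds along the chain from an oxygen on an aromatic ring, gives a 2.1-fold lower number from compound 2 to compound 4 (0.33 log units; beyond the scatter) and so a modest gain in inhibition. Going by these compounds alone, this is the first comparison here in which only this ring changes, so the shift can be tied to this one swap, while the core and the rest of the chain stay the same. It shows that this position accepts the larger ring, which has 10 heavy atoms instead of 6, without any loss of inhibition, but no measurement shown says why the number falls.

As far as these compounds go, whether all the fluorines are needed for this step remains open. Also open, from the compounds shown here alone, is what a single fluorine, a methoxy group or a pyridine ring in place of the phenyl would give on this same core and chain.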